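The source may report more compounds than this note shows. Statements on the series, on what has been measured and on what is new or still open speak of the compounds shown alone.

Compound 1 `CC(=O)N1N=C(c2cc(O)c(O)c([N+](=O)[O-])c2)CC1c1nccs1` in an assay on isolated protein for inhibition of Amine oxidase [flavin-containing] A (Homo sapiens), read by fluorescence (a higher number here means a weaker inhibitor, a lower number a stronger inhibitor), gives 84600 nM.
Compound 2 `CC(=O)N1N=C(c2cc(O)c(O)c([N+](=O)[O-])c2)CC1c1cccs1` gives 86300 nM.
Compound 3 `CC(=O)N1N=C(c2cc(O)c(O)c([N+](=O)[O-])c2)CC1c1cccc(C#N)c1` gives 70600 nM.

Compound 3 sits at the low end of these three numbers, but the steps of a 1.2-fold lower number from compound 1 to compound 3 (0.08 log units; within the scatter) and a 1.2-fold lower number from compound 2 to compound 3 (0.09 log units; within the scatter) both lie within the scatter, so the three cannot be told apart. Compound 4 `CC(=O)N1N=C(c2cc(O)c(O)c([N+](=O)[O-])c2)CC1c1cccc(O)c1` differs from compound 3 in one place: hydroxy in place of cyano on an aromatic carbon. For the measured compounds named here, none of the measured steps exchanges a group on this aromatic ring; all three, including a 1.0-fold higher number from compound 1 to compound 2 (0.01 log units; within the scatter), change the group on the saturated ring carbon and stay within the scatter. Going by the values given here, with no direct precedent, a step no larger than the scatter is expected, a 1.0-fold lower number from compound 3 to compound 4 (0.00 log units; within the scatter). Compound 4 is therefore estimated at 70000 nM, with a range from 30000 nM to 160000 nM.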

Compound 4, half-maximal inhibitory concentration: 87000 nM
Beside the measured number, compound 4's estimate is 1.2-fold (0.09 log units) below it, within the range that was stated.
By their numbers in this assay, from the lowest: compounds 3, 1, 2 and 4 (each within the scatter of the next).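

For the compounds shown here, this is the first exchange on the aromatic ring itself, and replacing cyano with hydroxy, which brings a hydrogen-bond donor, stays inside the scatter, with a 1.2-fold higher number from compound 3 to compound 4 (0.09 log units; within the scatter). On the saturated ring carbon, 3-hydroxyphenyl likewise cannot be told apart from the other groups, with a 1.0-fold higher number from compound 2 to compound 4 (0.00 log units; within the scatter) and a 1.0-fold higher number from compound 1 to compound 4 (0.01 log units; within the scatter). At this aromatic carbon, the two groups therefore give no readable difference, and nothing available offers an explanation. Still open, on these data alone, is whether an amine or a carboxylic acid at this aromatic carbon would move the number beyond the scatter.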